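A few compounds are considered here, and "the series" means these few. Any claim that something is new, unique, unknown or untested is made for them only; others in the source may bear on it.

Series notes, cytotoxicity.

Compound 1 `COc1ccc(/C=C2\CCC/C(=C\c3cccc(OC)c3OC)C2=O)cc1` and compound 3 `COc1ccc(/C=C2\CCC/C(=C\c3ccc(OC)c(OC)c3)C2=O)cc1` share the same atoms joined differently; the difference between the two cores is not broken down here. In a functional assay on SW-620 cells (Homo sapiens) for cytotoxicity, read by MTT assay, with a stated time of 72 h (on this read-out lower numbers stand for stronger inhibition and higher numbers for weaker inhibition), compound 1 gives 13600 nM, and compound 3 gives 6600 nM; the two sit with a gap beyond the usual scatter, compound 1 being the higher number of the two.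

Compound 2 `COc1cccc(/C=C2\CCC/C(=C\c3cccc(O)c3)C2=O)c1OC` differs from compound 1 by one change, (3-hydroxyphenyl in place of 4-methoxyphenyl on a double-bonded chain carbon bound to a double-bonded ring carbon). In this assay compound 2 gives 6400 nM, a step of a 2.1-fold lower number from compound 1 to compound 2 (0.33 log units; beyond the scatter). Compound 2 and compound 3 lie within the scatter of each other.

Compound 4 `COc1ccc(/C=C2\CCC/C(=C\c3cccc(O)c3)C2=O)cc1OC` carries the same change relative to compound 3: 3-hydroxyphenyl in place of 4-methoxyphenyl on a double-bonded chain carbon bound to a double-bonded ring carbon. The place is identical in both cases. Among the compounds with values here, the step from compound 3 to compound 4 is expected to be a 2.0-fold lower number from compound 3 to compound 4 (0.30 log units; within the scatter), resting on the single earlier instance in compound 1 going to compound 2, which gives thin support. Compound 4 is therefore estimated at 3300 nM, within 1500 nM to 7500 nM.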

Compound 4, half-maximal inhibitory concentration: 1900 nM
Compound 4: the middle estimate sits 1.7-fold (0.24 log units) above what was measured, within the range that was stated.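

In this assay, 3-hydroxyphenyl in place of 4-methoxyphenyl gives a 3.5-fold lower number from compound 3 to compound 4 (0.54 log units; beyond the scatter), so the change carries from one core to the other in the same direction, and the two step sizes cannot be told apart: the same change on two cores in this assay, a 2.1-fold lower number (0.33 log units; beyond the scatter) from compound 1 to compound 2 and a 3.5-fold lower number (0.54 log units; beyond the scatter) from compound 3 to compound 4, 1.6-fold (0.21 log units) apart, within the scatter of two such steps. Two cores support transfer only between these pairs, not a rule for every core in the series. The steps alone give no reason why the change lowers the number.

As far as these compounds go, it remains open whether an amine or a carboxylic acid in place of the hydroxy group of the 3-hydroxyphenyl would give a similar step. Also open, from the compounds shown here alone, is whether the change would behave the same way outside this assay.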